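The compounds below may be only part of what the source reports. "The series", "measured", "known", "first", "only" and "open" are said of these compounds alone.

Measured so far in a functional assay for antagonist activity at P2X purinoceptor 7 (Rattus norvegicus), read by FLIPR and calcium flux; on this read-out higher numbers stand for weaker inhibition and lower numbers for stronger inhibition:

Compound 1, `Cc1ccccc1N/C(=N\C#N)N1CCN(C(=O)Cc2ccoc2)C(c2ccccc2)C1` — 250 nM
Compound 2, `Cc1ccccc1N/C(=N\C#N)N1CCN(C(=O)Cc2cccnc2)C(c2ccccc2)C1` — 390 nM

Compound 2 has the number with the less favorable reading of the two, but it sits within the scatter of compound 1: the step of a 1.6-fold higher number from compound 1 to compound 2 (0.19 log units; within the scatter) is too small to count as a real difference. In other words, swapping one small aromatic ring for another at the saturated chain carbon bound to the carbonyl carbon left the inhibitory potency essentially unchanged.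

Compound 3, `Cc1ccccc1N/C(=N\C#N)N1CCN(C(=O)Cc2cccs2)C(c2ccccc2)C1`, makes a change of the same kind: thiophen-2-yl in place of pyridin-3-yl on a saturated chain carbon bound to a carbonyl carbon. For the measured compounds named here, the only measured step that bears on it is a 1.6-fold higher number from compound 1 to compound 2 (0.19 log units; within the scatter), which stayed within the scatter. On that basis no step beyond the scatter is expected in this assay either, in neither direction; the estimated step of a 1.3-fold lower number from compound 2 to compound 3 (0.11 log units; within the scatter) simply mirrors the small movement already seen. Compound 3 is therefore expected to give about 300 nM, with a likely range from 120 nM to 750 nM.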

Compound 3, half-maximal inhibitory concentration: 150 nM
Compound 3: the middle estimate sits 2.0-fold (0.30 log units) above what was measured; measured number inside the range.
By their numbers in this assay, from the lowest: compounds 3, 1 and 2 (each within the scatter of the next, the first and the last beyond it).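

In this assay, the position on a saturated chain carbon bound to a carbonyl carbon now shows a step that clears the scatter: thiophen-2-yl in place of pyridin-3-yl gives a 2.6-fold lower number from compound 2 to compound 3 (0.41 log units; beyond the scatter), a modest change, so these two rings are not fully interchangeable here. By contrast, thiophen-2-yl in place of furan-3-yl gives a 1.7-fold lower number from compound 1 to compound 3 (0.22 log units; within the scatter), so those two groups cannot be told apart in this read-out, and the only gap beyond the scatter among the three compounds is the one that separates the pyridin-3-yl and thiophen-2-yl compounds. No available evidence explains that gap.

The change from pyridin-3-yl to thiophen-2-yl alters both the ring size and the hetero atom, from a six-membered ring with nitrogen to a five-membered ring with sulfur, so these compounds cannot show which of the two matters. As far as these compounds go, it also remains open how a thiophen-3-yl or plain phenyl ring, an amine, or a longer chain carrying the thiophen-2-yl ring would behave at this position.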